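Cytotoxicity of a dimethoxyphenyl variant in the chalcone amide series

The source may report more compounds than this note shows. Statements on the series, on what has been measured and on what is new or still open speak of the compounds shown alone.

Measured so far:
- compound 1, `COC(=O)c1cc(-c2cccc(NC(=O)c3ccc(/C=C/C(=O)c4cccc(F)c4)cc3)c2)on1`: > 40 ug/mL
- compound 2, `COC(=O)c1cc(-c2cccc(NC(=O)c3ccc(/C=C/C(=O)c4cc(OC)c(OC)c(OC)c4)cc3)c2)on1`: > 50 ug/mL
- compound 3, `COC(=O)c1cc(-c2cccc(NC(=O)c3ccc(/C=C/C(=O)c4ccc(C)c(F)c4)cc3)c2)on1`: > 50 ug/mL

In an ADME assay on Vero cells (Chlorocebus sabaeus) for cytotoxicity, read by MTT assay, with a stated time of 72 h (a higher number here means that more compound is tolerated, a lower number that less compound is tolerated), compound 1 reaches only a limit of the assay, > 40 ug/mL. Compound 2 likewise gives only a limit, > 50 ug/mL. Compound 3 also stands at a limit, > 50 ug/mL, so its position among the three cannot be fixed more closely; all three values are limits rather than numbers (the limit of > 40 ug/mL in this assay, at which 1 of the 3 values shown sits, (the limit of > 50 ug/mL in this assay, at which 2 of the 3 values shown sit)).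

Compound 4, `COC(=O)c1cc(-c2cccc(NC(=O)c3ccc(/C=C/C(=O)c4ccc(OC)c(OC)c4)cc3)c2)on1`, differs from compound 3 by 3,4-dimethoxyphenyl in place of 3-fluoro-4-methylphenyl on a carbonyl carbon. The measured steps that bear on this change, a step that the two limits leave unreadable from compound 1 to compound 2, a step that the two limits leave unreadable from compound 1 to compound 3 and a step that the two limits leave unreadable from compound 2 to compound 3, cannot be read in size because each ends at a limit. Compound 2, carrying a trimethoxyphenyl group, sits at a limit, so a dimethoxyphenyl group in compound 4 is expected to behave in the same way, with no step beyond the scatter, a number no higher from compound 3 to compound 4 (the limit leaves the size open). Compound 4 is therefore estimated at 50 ug/mL, within 30 ug/mL to 90 ug/mL.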

Compound 4, half-maximal cytotoxic concentration: > 50 ug/mL
Compound 4 was reported as a limit; the forecaster's own chance of this, stated with the estimate: 80%; the middle value sits exactly at the limit.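

In this assay compound 4 reaches only a limit, > 50 ug/mL. Going by these compounds alone, compound 1, compound 2 and compound 3 also stand at limits, so no step to compound 4 can be read in size. The compounds shown leave open at what actual concentration any of them harms the cells, and whether changing the group on the carbonyl carbon alters it.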